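Removing One Methyl from an Inactive Acetyl Compound

A few compounds are considered here, and "the series" means these few. Any claim that something is new, unique, unknown or untested is made for them only; others in the source may bear on it.

Values in a functional assay on MV4-11 cells (Homo sapiens) for inhibition, read by resazurin assay, with a stated time of 72 h; a lower number here means a stronger inhibitor of growth, a higher number a weaker inhibitor of growth:
- compound 1 `O=C1NCCC12CCN(c1c(Cl)cncc1-c1cc[nH]c1)CC2`: 1050 nM
- compound 2 `O=Cc1cc(-c2cncc(Cl)c2N2CCC3(CCNC3=O)CC2)co1`: 5150 nM
- compound 3 `CC(=O)c1sccc1-c1cncc(Cl)c1N1CCC2(CCNC2=O)CC1`: > 100000 nM

Compound 3 has no numerical value, and its entry is only a limit. The series thus contains (the limit of > 100000 nM in this assay, at which 1 of the 3 values shown sits).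

Compound 4 `O=Cc1sccc1-c1cncc(Cl)c1N1CCC2(CCNC2=O)CC1` differs from compound 3 by a single change, hydrogen in place of methyl on a carbonyl carbon, turning 2-acetylthiophen-3-yl into 2-formylthiophen-3-yl. Going by the values given here, no measured step makes exactly this change. The closest evidence comes from swaps of the whole substituent, which show a 4.9-fold higher number from compound 1 to compound 2 (0.69 log units; beyond the scatter) and an at least 95-fold higher number from compound 1 to compound 3 (1.97 log units; beyond the scatter). Compound 2 also carries a formyl group, and the step away from it shows an at least 19-fold higher number from compound 2 to compound 3 (1.28 log units; beyond the scatter). That step changes more than the methyl, so only part of it can be expected to carry over, and a lower number is expected, of uncertain size. The estimate corresponds to an expected at least 5.0-fold lower number from compound 3 to compound 4 (0.69 log units; beyond the scatter). For compound 4 the expected value in this assay is 20000 nM, with an estimated range of 4000 nM to 100000 nM.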

Compound 4, concentration for 50% growth inhibition: 28700 nM
The estimate for compound 4 lay 1.4-fold (0.16 log units) below the measured number, and the stated range covers the measured number.
By their numbers in this assay, from the lowest: compound 1; then compound 2; then compound 4. At a limit, above all of these: compound 3.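

In this assay the entry for compound 3 is a limit and not a number: (the limit of > 100000 nM in this assay, at which 1 of the 4 values shown sits). Losing the one methyl on the carbonyl carbon, acetyl to formyl, still gives a readable step (an at least 3.4-fold lower number from compound 3 to compound 4 (0.54 log units; beyond the scatter)), so this single change brings the compound back to a measured value, although the true size of the step stays unknown. Formyl alone does not bring back the level of the other compounds, since 2-formylthiophen-3-yl still compares poorly with both 5-formylfuran-3-yl (a 5.6-fold higher number from compound 2 to compound 4 (0.75 log units; beyond the scatter)) and 1H-pyrrol-3-yl (a 27-fold higher number from compound 1 to compound 4 (1.44 log units; beyond the scatter)).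

The compounds shown leave open whether a carboxylic acid, a hydroxymethyl group or a primary amide in place of the formyl on 2-formylthiophen-3-yl would lower the number further. They also leave open how a longer chain on the same carbonyl carbon would compare with acetyl.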